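From tert-butyl to dimethylamino in a cytotoxic series

This account rests on a few compounds, and the source may have more. Where it says the series, first, only, none or still open, it means among the compounds named here.

Of the compounds shown here, two sharing one core have been measured so far in a functional assay on MCF7 cells (Homo sapiens) for cytotoxicity, read by MTT assay and propidium iodide staining, with a stated time of 24 h; a lower number here means a stronger inhibitor, a higher number a weaker inhibitor. In this test, compound 1 (`Cc1ccc(-c2nnc(SCC(=O)c3ccccc3)o2)c(O)c1`) gives 150 nM, and compound 2 (`CC(C)(C)c1ccc(-c2nnc(SCC(=O)c3ccccc3)o2)cc1`) gives 50 nM. Compound 2 therefore holds the lower of the two numbers, and its gap to compound 1 lies beyond the usual scatter of repeated measurements.

The next compound to be tested is compound 3 (`CN(C)c1ccc(-c2nnc(SCC(=O)c3ccccc3)o2)cc1`). It carries dimethylamino in place of tert-butyl on an aromatic carbon, para to a large group: dimethylamino in place of tert-butyl on an aromatic carbon. Going by the values given here, the two measured compounds differ in more than one place, so no measured step shows what this exchange does, and any forecast remains loose. Since compound 2 stands at 50 nM, the lower end of the little that is known, a modest weakening in this assay is expected, with the estimate being a 2.0-fold higher number from compound 2 to compound 3 (0.30 log units; within the scatter). A change within the scatter cannot be ruled out. Compound 3 is estimated at 100 nM, with an expected range of 30 nM to 330 nM.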

Compound 3, half-maximal inhibitory concentration: 210 nM
Compound 3: middle estimate off by 2.1-fold (0.32 log units), on the low side; measured number inside the range.
By their numbers in this assay, from the lowest: compound 2; then compounds 1 and 3 (each within the scatter of the next).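

In this assay, the exchange of tert-butyl for dimethylamino on an aromatic carbon, para to a large group, comes with a 4.2-fold higher number from compound 2 to compound 3 (0.62 log units; beyond the scatter). Going by these compounds alone, this is the first single-place comparison, and it shows that the number at this position depends on which of these two groups it carries, with the tert-butyl of compound 2 on the stronger side. Nothing at hand explains the size or direction of this step, and the counts alone, with dimethylamino bringing in a nitrogen and a hydrogen-bond acceptor, do not settle it.

With only these two groups compared at this carbon, the compounds shown leave open whether the nitrogen or some other difference between the groups accounts for the step, and a methoxy group, an isopropyl group or a diethylamino group there could help to separate those readings. They also leave open whether the same exchange would give a step of similar size with a different substitution elsewhere on the shared core, such as the hydroxyl carried by compound 1.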